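The source may report more compounds than this note shows. Statements on the series, on what has been measured and on what is new or still open speak of the compounds shown alone.

Of the compounds shown here, two of a shared core have been measured in an ADME assay on the whole organism (blood) for pharmacokinetics, with Canis familiaris (Canis lupus familiaris) as the target; on this read-out higher numbers stand for a longer-lived compound and lower numbers for a shorter-lived compound. Compound 1 `COCC1(COC)Oc2ccc(C#N)cc2[C@@H](N=C(NC#N)c2cccnc2)[C@@H]1O` gives 0.0467 h in this assay. Compound 2 `COCC1(COC)Oc2ccc(C#N)cc2[C@@H](Nc2ccc(=O)n(C(C)C)n2)[C@@H]1O` gives 0.0917 h in this assay. Compound 2 stands at the top of the two numbers, yet its gap to compound 1 falls within the usual scatter of repeated measurements, so the two compounds cannot be told apart on this read-out; both are cleared from dog blood quickly.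

Compound 3 `COCC1(COC)Oc2ccc(C#N)cc2[C@@H](Nc2ccc(=O)n(CC#N)n2)[C@@H]1O` is the next compound and has not yet been measured. It differs from compound 2 in one place: cyanomethyl in place of isopropyl on an aromatic nitrogen. Going by the values given here, no step between two measured compounds that differ only in this way is known, so nothing in the data shows how this change acts on half-life. Among the compounds with values here, with both measured compounds so close together and no step to lean on, the expectation is that the step from compound 2 to compound 3 stays within the scatter, in either direction: a 1.1-fold lower number from compound 2 to compound 3 (0.06 log units; within the scatter) is what is estimated. Compound 3 is therefore expected to give about 0.08 h in this assay, within a range of 0.03 h to 0.22 h.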

Compound 3, half-life: 0.0517 h
Beside the measured number, compound 3's estimate is 1.5-fold (0.19 log units) above it; the range from low to high includes it.
By their numbers in this assay, from the lowest: compounds 1, 3 and 2 (each within the scatter of the next).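

Going by these compounds alone, this is the first pair that differs in one place only, so it gives the first direct view of the group on the aromatic nitrogen in this assay. Cyanomethyl in place of isopropyl gives a 1.8-fold lower number from compound 2 to compound 3 (0.25 log units; within the scatter) in this pair. That step is within the scatter of repeated measurements. This pair shows no real effect of the change on half-life. No measured property of either group is available to bear on this result.

Going by these compounds, whether this position matters for half-life at all stays open, since a single swap within the scatter cannot settle it, and a group of a different kind on this nitrogen, such as an amine, a carboxylic acid or a longer carbon chain, might give a step beyond the scatter. Equally open, on these data alone, is whether cyanomethyl in place of isopropyl would give a step of similar size on a compound that carries a different group elsewhere on the shared core.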